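Quinazoline ether series: cytotoxicity notes on compound 3

The source may report more compounds than this note shows. Statements on the series, on what has been measured and on what is new or still open speak of the compounds shown alone.

For the measured compounds named here, compound 2 `Cc1cccc(C)c1Oc1nc(Nc2ccc(C#N)cc2)nc2ccccc12` gives 35000 nM in an ADME assay on MT4 cells (Homo sapiens) for cytotoxicity, read by MTT assay, with a stated time of 4 days (a lower number here means that less compound is tolerated, a higher number that more compound is tolerated), the lowest number among the two measured members. Its nearest neighbour is compound 1 `Cc1cccc(Oc2nc(Nc3ccc(C#N)cc3)nc3ccccc23)c1`, which in this assay gives 355000 nM. Going by the values given here, the one measured step, a 10-fold lower number from compound 1 to compound 2 (1.01 log units; beyond the scatter), lies beyond the scatter and is the only comparison available for the ether substituent.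

Compound 3 `N#Cc1ccc(Nc2nc(Oc3ccc(Br)cc3)c3ccccc3n2)cc1` is not yet measured. The change from compound 2 is 4-bromophenyl in place of 2,6-dimethylphenyl on an oxygen on an aromatic ring. Among the compounds with values here, no measured pair carries this exact change. The step from compound 1 to compound 2 bears on it only in that both concern the same place; that step was large, and it shows that the aryl group on the ether oxygen moves the number in this assay substantially. Since compound 3 gives up the 2,6-dimethylphenyl that accompanied the lowest number, a return toward the value of compound 1 is expected, but with wide uncertainty.

For compound 3 in this assay the expected value is 120000 nM, with a range from 35000 nM to 400000 nM, which is the expected step of a 3.4-fold higher number from compound 2 to compound 3 (0.54 log units; beyond the scatter).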

Compound 3, half-maximal cytotoxic concentration: 215000 nM
Estimate against measurement, compound 3: 1.8-fold (0.25 log units) below; the measured number falls inside the stated range.
By their numbers in this assay, from the lowest: compound 2; then compounds 3 and 1 (each within the scatter of the next).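

In this assay the change to 4-bromophenyl on the oxygen gives a 6.1-fold higher number from compound 2 to compound 3 (0.79 log units; beyond the scatter) and so the standing of compound 2 no longer rests on a single comparison: it now stands apart from two other aryl ethers, each by a step beyond the scatter. Against 3-methylphenyl the same 4-bromophenyl gives a 1.7-fold lower number from compound 1 to compound 3 (0.22 log units; within the scatter) so these two groups are not separated by this assay, and a change of aryl group at this place does not by itself move the number. Nothing at hand gives a reason for the separate standing of compound 2.

The compounds shown leave open whether the lower number of compound 2 goes with the pair of methyl groups or with some other feature of 2,6-dimethylphenyl, as no other aryl group with two substituents stands among them. Also open, on these data alone, is how this assay responds to a saturated group such as cyclohexyl on the oxygen, or to an amine or a carboxylic acid on the aryl ring.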